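Methyl for nitro on the fused benzene ring of the series

The source may hold more compounds than are shown below. What is called first, only, known or untested is meant among the compounds shown, and "the series" means these compounds.

Measured compounds:
compound 1 `O=C(Cc1cccnc1)c1cc2ccccc2[nH]1`, 13%
compound 2 `O=C(Cc1cccnc1)c1cc2cc(Cl)ccc2[nH]1`, 24%
compound 3 `O=C(Cc1cccnc1)c1cc2cc([N+](=O)[O-])ccc2[nH]1`, "not active" (no number reported)

In an in vitro assay on P815B cells for inhibition of Indoleamine 2,3-dioxygenase 1 (Mus musculus), tested at 20 uM (on this read-out lower numbers stand for less inhibition and higher numbers for more inhibition at the one concentration tested (going by the name of the read-out)), compound 1 gives 13%. Compound 2 gives 24%, and the one shown step, a number 11 percentage points higher from compound 1 to compound 2 (beyond the scatter), is beyond the scatter. Compound 3 gives "not active" (no number reported); no number stands for it, so its place relative to compound 1 and compound 2 cannot be set, only that it is reported as inactive.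

Compound 4 `Cc1ccc2[nH]c(C(=O)Cc3cccnc3)cc2c1` is not yet measured. It differs from compound 3 by methyl in place of nitro on an aromatic carbon.

Going by the values given here, no measured step bears on a methyl entering or a nitro leaving at this position. Among the compounds with values here, the only measured step, a number 11 percentage points higher from compound 1 to compound 2 (beyond the scatter), concerns a different group at the same place and was modest. Within the data shown here, with compound 3 carrying no number, no step from compound 3 to compound 4 can be sized. Compound 4 is expected to lie near the range spanned by compound 1 and compound 2, and the estimated value for compound 4 is 18%, within 4% to 32%.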

Compound 4, a percentage reported as inhibition, at one concentration (the size of the read-out at that concentration, not a potency): 21%
The estimate for compound 4 lay 3 percentage points below the measured number; the measured number falls inside the stated range.
By their numbers in this assay, from the lowest: compounds 1, 4 and 2 (each within the scatter of the next, the first and the last beyond it).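

In this assay, methyl on this aromatic carbon cannot be told apart from chloro, a number 3 percentage points lower from compound 2 to compound 4 (within the scatter), or from hydrogen, a number 8 percentage points higher from compound 1 to compound 4 (within the scatter), so compound 4 does not separate the two, although the step of a number 11 percentage points higher from compound 1 to compound 2 (beyond the scatter) lies beyond the scatter. Compound 4 also shows that this place can carry a group other than chloro and still give a number, while the step from compound 3 to compound 4 cannot be read, as the nitro compound has no number. Nothing available bears on what lies behind these results.

On these data alone, it remains open whether an amine or a carboxylic acid on this aromatic carbon would stand beyond the scatter of compound 1. As far as these compounds go, it is also open whether the report of no activity for compound 3 is particular to nitro or would extend to a nitrile.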